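This account rests on a few compounds, and the source may have more. Where it says the series, first, only, none or still open, it means among the compounds named here.

In an ADME assay on the whole organism (strain CD-1) for metabolic stability, with Mus musculus as the target, at a dose of 3 mg/kg by the intravenous route (a lower number here means that the compound disappears faster, a higher number that the compound lasts longer), compound 2 `C[C@H](CCCOc1ccccc1CN(C)C(=O)c1ccc(-c2ccco2)cc1)CC(=O)O` gives 3.9 h, within the scatter of compound 1 `CN(Cc1ccccc1OCCCCC(C)(C)C(=O)O)C(=O)c1ccc(-c2ccco2)cc1` at 4.6 h. Compound 3 `C[C@@H](CCCOc1ccccc1CN(C)C(=O)c1ccc(-c2ccco2)cc1)CC(=O)O` differs from compound 2 in this way: the two compounds have the same atoms and bonds and differ only in configuration as drawn: 1 of 1 stereo elements differ; a stereocentre at a saturated chain carbon is drawn R in compound 2 and S in compound 3. Among the measured compounds shown here, the one measured step, a 1.2-fold lower number from compound 1 to compound 2 (0.07 log units; within the scatter), swaps a substituent on the chain, and no measured pair tests this stereocentre, so it is only a loose guide to size. No step beyond the scatter is therefore expected, and no direction can be assigned. The expected change is no change at the digits printed from compound 2 to compound 3 (within the scatter). For compound 3 the estimated value is 3.9 h, with an expected range of 1.9 h to 7.5 h.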

Compound 3, half-life: 2 h
For compound 3 the middle estimate is 2.0-fold (0.29 log units) above the measured one, and the stated range covers the measured number.
By their numbers in this assay, from the lowest: compounds 3, 2 and 1 (each within the scatter of the next, the first and the last beyond it).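

Among the compounds shown here, the first pair to test this stereocentre gives a 2.0-fold lower number from compound 2 to compound 3 (0.29 log units; within the scatter), so in this pair the configuration at the saturated chain carbon has no effect that can be told from the scatter. Set against the 2-carboxy-2-methylpropyl chain, the S form gives a 2.3-fold lower number from compound 1 to compound 3 (0.36 log units; beyond the scatter), whereas the R form stays within the scatter of compound 1. The pair reads on configuration alone: the fact that compounds 2 and 3 differ only in the configuration as drawn

On these data alone, it remains open how this assay responds when a tetrazole replaces the carboxylic acid, or when a longer chain carries the stereocentre.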